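Meta-substitution on both aryl rings of a thiohydantoin series

The source may report more compounds than this note shows. Statements on the series, on what has been measured and on what is new or still open speak of the compounds shown alone.

Measured so far in a functional assay on DU-145 cells (Homo sapiens) for antiproliferative activity, read by propidium iodide staining, with a stated time of 96 h; on this read-out higher numbers stand for weaker inhibition and lower numbers for stronger inhibition:
compound 1, `CC1(C)C(=O)N(c2ccc(S(F)(F)(F)(F)F)cc2)C(=S)N1c1ccc(C(F)(F)F)cc1`, gives 100000 nM;
compound 2, `CC1(C)C(=O)N(c2ccc(S(F)(F)(F)(F)F)cc2)C(=S)N1c1cccc(C(F)(F)F)c1`, gives 100000 nM;
compound 3, `CC1(C)C(=O)N(c2cccc(S(F)(F)(F)(F)F)c2)C(=S)N1c1ccc(C(F)(F)F)cc1`, gives 39800 nM.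

Compound 1 and compound 2 share one core and differ by 3-(trifluoromethyl)phenyl in place of 4-(trifluoromethyl)phenyl on an amide-type nitrogen in a ring. That change made no change at the digits printed from compound 1 to compound 2 (within the scatter). Compound 3 carries a different core; how its core differs from that of compound 1 is not broken down here, but in this assay compound 3 gives the lowest of the three numbers, and its gaps to compound 1 and to compound 2 are both beyond the scatter.

Compound 4, `CC1(C)C(=O)N(c2cccc(S(F)(F)(F)(F)F)c2)C(=S)N1c1cccc(C(F)(F)F)c1`, has not yet been measured. It differs from compound 3 by 3-(trifluoromethyl)phenyl in place of 4-(trifluoromethyl)phenyl on an amide-type nitrogen in a ring, the same change as from compound 1 to compound 2, at the same place on the ring. Because that change gave no change at the digits printed from compound 1 to compound 2 (within the scatter), compound 4 is expected to stay close to compound 3, with a 1.3-fold higher number from compound 3 to compound 4 (0.10 log units; within the scatter) as the expected step. Compound 4 is therefore estimated at 50000 nM, within 20000 nM to 100000 nM.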

Compound 4, half-maximal inhibitory concentration: 100000 nM
For compound 4 the middle estimate is 2.0-fold (0.30 log units) below the measured one; low and high end bracket the measured number.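

In this assay, 3-(trifluoromethyl)phenyl in place of 4-(trifluoromethyl)phenyl gave a 2.5-fold higher number from compound 3 to compound 4 (0.40 log units; beyond the scatter) on the core of compound 3, while the same change on the core of compound 1 gave no change at the digits printed from compound 1 to compound 2 (within the scatter) in the same assay. Although only the newer step lies beyond the scatter, the two steps cannot be told apart: the same change on two cores in this assay, no change at the digits printed (within the scatter) from compound 1 to compound 2 and a 2.5-fold higher number (0.40 log units; beyond the scatter) from compound 3 to compound 4, 2.5-fold (0.40 log units) apart, within the scatter of two such steps. For the compounds shown here, this shows that the change behaved alike within the scatter on these two cores, but it does not show that the core has no influence on the step, and a single pair of steps in one assay cannot say how the change would carry to any other core.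

The compounds shown leave open whether a nitrile or a carboxylic acid in place of the trifluoromethyl group would respond in the same way to this change of position. They also leave open what longer chains in place of the two methyl groups would do to the step.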